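From 3-methoxyphenyl to (4-chlorophenyl)carbonyl

The source may report more compounds than this note shows. Statements on the series, on what has been measured and on what is new or still open speak of the compounds shown alone.

Measured in a functional assay on KMS-11 cells (Homo sapiens) for antiproliferative activity, read by CellTiter-Glo, with a stated time of 72 h; a lower number here means a stronger inhibitor, a higher number a weaker inhibitor:
- Compound 1 `COc1ccc(C(=O)N(Cc2ccncc2)Cc2cccc(OCCc3ccc(Br)cc3)c2)cc1`: 8400 nM
- Compound 2 `COc1ccc(C(=O)N(Cc2ccncc2)Cc2cccc(OCc3ccc(F)cc3)c2)cc1`: 22700 nM
- Compound 3 `COc1ccc(C(=O)N(Cc2ccncc2)Cc2cccc(OCc3cccc(OC)c3)c2)cc1`: 16900 nM

Compound 3 has no clear place in this small series, since its steps to the other two lie within the scatter: a 1.3-fold lower number from compound 2 to compound 3 (0.13 log units; within the scatter) and a 2.0-fold higher number from compound 1 to compound 3 (0.30 log units; within the scatter). For the measured compounds named here, the only step beyond the scatter is a 2.7-fold higher number from compound 1 to compound 2 (0.43 log units; beyond the scatter), and it is modest.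

Compound 4 `COc1ccc(C(=O)N(Cc2ccncc2)Cc2cccc(OCC(=O)c3ccc(Cl)cc3)c2)cc1` carries (4-chlorophenyl)carbonyl in place of 3-methoxyphenyl on a saturated chain carbon bound to an oxygen on an aromatic ring.

All three measured steps change the group at this same place, and none is large. In this assay, therefore, no step beyond the scatter is expected. Any small shift is expected to lean toward compound 1 at 8400 nM, whose 4-bromobenzyl resembles the entering group more than 3-methoxyphenyl does. The estimated change is a 1.4-fold lower number from compound 3 to compound 4 (0.15 log units; within the scatter). For compound 4 the estimate is 12000 nM, with an expected range from 6000 nM to 24000 nM.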

Compound 4, half-maximal inhibitory concentration: 18500 nM
Beside the measured number, compound 4's estimate is 1.5-fold (0.19 log units) below it; measured number inside the range.
By their numbers in this assay, from the lowest: compounds 1, 3, 4 and 2 (each within the scatter of the next, the first and the last beyond it).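

In this assay, the (4-chlorophenyl)carbonyl group brings a carbonyl into this place on the chain, yet the steps stay small: a 1.1-fold higher number from compound 3 to compound 4 (0.04 log units; within the scatter) and a 1.2-fold lower number from compound 2 to compound 4 (0.09 log units; within the scatter). For the compounds shown here, only the step involving the 4-bromobenzyl compound passes the scatter, a 2.2-fold higher number from compound 1 to compound 4 (0.34 log units; beyond the scatter), and it is modest, so compound 1 now stands apart from compound 2 and compound 4, while compound 3 goes against any clean split, with a 2.0-fold higher number from compound 1 to compound 3 (0.30 log units; within the scatter). Nothing measured here accounts for these values.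

Compound 4 differs from compound 3 in both the carbonyl and the chlorine, so the part each plays cannot be read separately. Going by these compounds, whether an amine or a carboxylic acid at the end of this chain, or a longer chain, would move the number further remains open.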